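The source may hold more compounds than are shown below. What is called first, only, known or untested is meant among the compounds shown, and "the series" means these compounds.

Compound 1 `COc1cc(Oc2ccc(NC(=O)Nc3cccc(C(F)(F)F)c3)cc2)ncn1` is the weaker of the two measured compounds in an assay on isolated protein for inhibition of serine/threonine-protein kinase TNNI3K (Homo sapiens); on this read-out higher numbers stand for weaker inhibition and lower numbers for stronger inhibition: compound 1 gives 4000 nM, whereas compound 2 `CNc1cc(Oc2c(F)cc(NC(=O)Nc3cccc(C(F)(F)F)c3)cc2F)ncn1` gives 20 nM, a gap well beyond the scatter. Compound 3 `Cc1cc(Oc2ccc(NC(=O)Nc3cccc(C(F)(F)F)c3)cc2)ncn1` differs from compound 1 in one place, (methyl in place of methoxy on an aromatic carbon). Among the compounds with values here, no measured pair isolates this change, so only a modest step is expected, with no direction that clearly rises above the scatter; the step of a 1.3-fold higher number from compound 1 to compound 3 (0.10 log units; within the scatter) is what the expectation amounts to. Compound 3 is accordingly estimated at 5000 nM, with a likely range from 1500 nM to 16000 nM.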

Compound 3, half-maximal inhibitory concentration: 160 nM
The estimate for compound 3 lay 31-fold (1.49 log units) above the measured number; measured number outside the range, below it.
By their numbers in this assay, from the lowest: compound 2; then compound 3; then compound 1.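

Methyl in place of methoxy on this aromatic carbon, next to the ring nitrogen, gives in this assay a 25-fold lower number from compound 1 to compound 3 (1.40 log units; beyond the scatter) with the rest of the structure unchanged. This shows that the group at this one position can by itself shift the number by a large step, and that the smaller methyl is the better of the two groups compared here. No available evidence accounts for this step.

Going by these compounds, what an ethyl group, a chlorine or an unsubstituted amine would give at this carbon remains open. So does whether the same exchange would carry over to the core of compound 2.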